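A few compounds are considered here, and "the series" means these few. Any claim that something is new, unique, unknown or untested is made for them only; others in the source may bear on it.

Three related compounds have numbers in a functional assay on MDA-MB-231 cells (Homo sapiens) for antiproliferative activity, read by sulforhodamine B assay, with a stated time of 72 h; a higher number here means a weaker inhibitor, a lower number a stronger inhibitor: compound 1 `CC(C)C[C@H](NC(=O)CSc1cc(NS(=O)(=O)c2ccc(Cl)cc2)c2ccccc2c1O)B(O)O` gives 6190 nM, compound 2 `CC(=O)Nc1ccc(S(=O)(=O)Nc2cc(SCC(=O)N[C@@H](CC(C)C)B(O)O)c(O)c3ccccc23)cc1` gives 4450 nM, and compound 3 `CC(=O)Nc1ccc(S(=O)(=O)Nc2cc(SCCC(=O)N[C@@H](CC(C)C)B(O)O)c(O)c3ccccc23)cc1` gives 2120 nM. Compound 2 therefore sits in the upper part of this small set. Putting acetamido in place of chloro on an aromatic carbon gives a 1.4-fold lower number from compound 1 to compound 2 (0.14 log units; within the scatter), so those two numbers cannot be told apart. Only compound 3 lies clearly lower than compound 2.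

Compound 4 `CC(=O)Nc1ccc(S(=O)(=O)Nc2cc(SC(C)C(=O)N[C@@H](CC(C)C)B(O)O)c(O)c3ccccc23)cc1` keeps everything in compound 2 except for one small change: methyl in place of hydrogen on a saturated chain carbon bound to a carbonyl carbon and a sulfur. In words, this is methyl in place of hydrogen on a saturated chain carbon bound to a carbonyl carbon and a sulfur. The aromatic swap says little about this, since it lies away from that chain. The most relevant measured change is the larger group on the carbon bound to sulfur, which gives a 2.1-fold lower number from compound 2 to compound 3 (0.32 log units; beyond the scatter), a modest step. Within the data shown here, that change lengthens the chain, whereas methyl makes a branch, and no measured compound has such a branch, so it is only a rough guide.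

A small move towards a lower number is expected, possibly no more than the scatter. The estimated change is a 1.4-fold lower number from compound 2 to compound 4 (0.14 log units; within the scatter). For compound 4 the expected value is 3200 nM, with an estimated range of 1500 nM to 6500 nM.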

Compound 4, half-maximal inhibitory concentration: 2800 nM
Estimate against measurement, compound 4: 1.1-fold (0.06 log units) above; the measured number falls inside the stated range.
By their numbers in this assay, from the lowest: compounds 3, 4, 2 and 1 (each within the scatter of the next, the first and the last beyond it).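

In this assay, methyl in place of hydrogen on the saturated chain carbon bound to a carbonyl carbon and a sulfur gives a 1.6-fold lower number from compound 2 to compound 4 (0.20 log units; within the scatter) and so leaves the two numbers indistinguishable. Among these compounds, the earlier compounds showed only what lengthening the chain does at this part of the molecule, whereas this is the first branch on that carbon. It shows that one added methyl at this position comes with no clear loss of antiproliferative activity, and equally with no clear gain, so a single small branch neither helps nor harms measurably in these cells. Nothing measured here bears on the reason for this result.

As far as these compounds go, a single methyl is a small probe, so it remains open whether a larger or different group on the same carbon, such as ethyl, isopropyl, phenyl, an amine or a carboxylic acid, would also leave the number within the scatter or would move it clearly. From the compounds shown here alone, it is also open whether the same methyl branch on the longer chain of compound 3 would change that compound's number.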